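Fluorophenyl for pyridyl on the piperazine amide

A few compounds are considered here, and "the series" means these few. Any claim that something is new, unique, unknown or untested is made for them only; others in the source may bear on it.

Measured so far:
- compound 1, `Cc1cccc(Cn2c(CN3CCN(C(=O)c4ccncc4)CC3)nc3ccccc32)c1`: 20.6%
- compound 2, `CC(C)Cn1c(CN2CCN(C(=O)C3CC3)CC2)nc2ccccc21`: 13.1%

In an assay on isolated protein for inhibition of aldehyde dehydrogenase 1A1 (Homo sapiens), read by spectrophotometry, tested at 10 uM (a higher number here means more inhibition at the concentration tested (going by the name of the read-out), a lower number less inhibition), compound 1 gives 20.6%. Compound 2 gives 13.1% in this assay. Of the two numbers, compound 1 has the higher one, but its gap to compound 2 lies within the usual scatter, so the two compounds cannot be told apart on these data. For the measured compounds named here, no pair of measured compounds differs in a single place, so no measured step is available as a guide.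

Compound 3, `Cc1cccc(Cn2c(CN3CCN(C(=O)c4ccc(F)cc4)CC3)nc3ccccc32)c1`, has not been measured. It differs from compound 1 as follows: 4-fluorophenyl in place of pyridin-4-yl on a carbonyl carbon. The shared core and the piperazine amide are kept; only the aromatic ring on the carbonyl carbon changes.

Going by the values given here, with no measured step on which to rest, the expected change in this assay from compound 1 to compound 3 is none beyond the scatter, and the step of a number 1.4 percentage points higher from compound 1 to compound 3 (within the scatter) is the estimate in either direction. For compound 3 the estimated value in this assay is 22%, with the range 5% to 40%.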

Compound 3, a percentage reported as inhibition, at one concentration (the size of the read-out at that concentration, not a potency): 27.1%
The estimate for compound 3 lay 5.1 percentage points below the measured number; measured number inside the range.
By their numbers in this assay, from the lowest: compounds 2, 1 and 3 (each within the scatter of the next, the first and the last beyond it).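

For the compounds shown here, compound 3 gives the first single-place step: in this assay, replacing pyridin-4-yl with 4-fluorophenyl on the carbonyl carbon amounts to a number 6.5 percentage points higher from compound 1 to compound 3 (within the scatter), so compound 1 and compound 3 cannot be told apart. At this position, on these two compounds, an aromatic ring with a ring nitrogen and a carbon-only ring bearing fluorine therefore read alike, and the ring nitrogen of pyridin-4-yl is not shown to be needed for the inhibition seen at the single tested concentration. Nothing measured here accounts for the size of this step, and the data give no explanation for it.

Open, on these data alone, is whether this position responds at all to a larger departure from these two rings, such as a carboxylic acid on the phenyl ring, a basic amine or a longer chain in place of the aromatic ring. Also open, as far as these compounds go, is whether a step beyond the usual scatter can be found here, and since each read-out is a single-concentration percentage rather than a potency, how compound 1 and compound 3 compare in potency remains unknown.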